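The source may report more compounds than this note shows. Statements on the series, on what has been measured and on what is new or still open speak of the compounds shown alone.

In a toxicity assay on L02 cells (Homo sapiens) for cytotoxicity, read by MTT assay, with a stated time of 72 h (on this read-out lower numbers stand for stronger inhibition and higher numbers for weaker inhibition), three compounds built on one shared core have been measured so far. Compound 1 `O=C1c2c[n+]([O-])c3ccccc3c2C(=O)c2c1c1ccccc1n2Cc1cn(C[C@@H](O)CO)nn1` gives 490 nM, compound 2 `O=C1c2c[n+]([O-])c3ccccc3c2C(=O)c2[nH]c3ccccc3c21` gives 400 nM, and compound 3 `CN(C)CCCCn1c2c(c3ccccc31)C(=O)c1c[n+]([O-])c3ccccc3c1C2=O` gives 300 nM. Compound 3 carries the lowest of the three numbers, yet the steps of a 1.6-fold lower number from compound 1 to compound 3 (0.21 log units; within the scatter) and a 1.3-fold lower number from compound 2 to compound 3 (0.12 log units; within the scatter) both stay within the scatter of repeated measurement, so on these numbers compound 3 cannot be set apart from the other two.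

Compound 4 `O=C1c2c[n+]([O-])c3ccccc3c2C(=O)c2c1c1ccccc1n2CCN1CCCC1` differs from compound 3 in a single place: pyrrolidin-1-yl in place of 2-(dimethylamino)ethyl on a saturated chain carbon, two bonds along the chain from an aromatic nitrogen. The measured steps that bear on this are the ones that change the chain hanging from the aromatic nitrogen of the core, namely a 1.6-fold lower number from compound 1 to compound 3 (0.21 log units; within the scatter) and a 1.3-fold lower number from compound 2 to compound 3 (0.12 log units; within the scatter), together with a 1.2-fold lower number from compound 1 to compound 2 (0.09 log units; within the scatter), which removes that chain entirely. Every one of these lies within the scatter, so exchanging one end of the chain for another is expected to make little difference in this assay. The step from compound 3 to compound 4 is expected to be no change at the digits printed from compound 3 to compound 4 (within the scatter). Compound 4 is therefore estimated at 300 nM in this assay, with a range from 150 nM to 650 nM.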

Compound 4, half-maximal inhibitory concentration: 930 nM
The estimate for compound 4 lay 3.1-fold (0.49 log units) below the measured number; measured number outside the range, above it.
By their numbers in this assay, from the lowest: compounds 3, 2, 1 and 4 (each within the scatter of the next, the first and the last beyond it).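

In this assay, going by these compounds alone, the chain on the aromatic nitrogen of the shared core turns out to matter: unlike the earlier steps, a 3.1-fold higher number from compound 3 to compound 4 (0.49 log units; beyond the scatter) passes beyond the scatter, as does a 2.3-fold higher number from compound 2 to compound 4 (0.37 log units; beyond the scatter) in the same direction, while a 1.9-fold higher number from compound 1 to compound 4 (0.28 log units; within the scatter) stays within it. Read one bond further out, the change replaces 4-(dimethylamino)butyl with 2-(pyrrolidin-1-yl)ethyl, so the number of heavy atoms stays the same, while the chain is shorter by name and its end is closed into a five-membered non-aromatic ring. Nothing available explains why this step is larger than the earlier ones.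

The shorter chain and the ring arrive together, so these compounds cannot show which of the two goes with the higher number. A 2-(dimethylamino)ethyl group or a 4-(pyrrolidin-1-yl)butyl group on the aromatic nitrogen would pull the two apart, and a six-membered amine ring such as piperidine or morpholine at the chain end would show whether the size of the ring counts.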